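A few compounds are considered here, and "the series" means these few. Any claim that something is new, unique, unknown or untested is made for them only; others in the source may bear on it.

Compound 1 `c1cc(-c2ccn[nH]2)c2c(c1)C(c1ncc[nH]1)CC2`: 52 nM
Compound 2 `Cn1nccc1-c1cccc2c1CCC2c1ncc[nH]1`: 278 nM

In a functional assay on CHO cells for agonist activity at Alpha-1A adrenergic receptor (Homo sapiens), read by FLIPR and calcium flux (on this read-out higher numbers stand for an effect only at larger amounts of compound and lower numbers for an effect already at smaller amounts), compound 2 gives 278 nM, the higher of the two measured numbers; compound 1 gives 52 nM, and the step of a 5.3-fold higher number from compound 1 to compound 2 (0.73 log units; beyond the scatter) is the only one measured. Compound 3 `c1ccc2c(c1)CCC2c1ncc[nH]1` differs from compound 2 by hydrogen in place of 1-methyl-1H-pyrazol-5-yl on an aromatic carbon. Among the measured compounds shown here, no measured step covers the removal of this whole group, so the methylation step offers only a loose guide. Both measured compounds carry the pyrazole; its loss is expected to raise the number, and the step of a 5.4-fold higher number from compound 2 to compound 3 (0.73 log units; beyond the scatter) is estimated accordingly, with wide uncertainty. For compound 3 the estimate is 1500 nM, within 300 nM to 8000 nM.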

Compound 3, half-maximal effective concentration: 473 nM
The estimate for compound 3 lay 3.2-fold (0.50 log units) above the measured number, and the stated range covers the measured number.
By their numbers in this assay, from the lowest: compound 1; then compounds 2 and 3 (each within the scatter of the next).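

Hydrogen in place of 1-methyl-1H-pyrazol-5-yl on this aromatic carbon gives a 1.7-fold higher number from compound 2 to compound 3 (0.23 log units; within the scatter), so the methylated group cannot be told apart from hydrogen here. The unmethylated group can: hydrogen in place of 1H-pyrazol-5-yl gives a 9.1-fold higher number from compound 1 to compound 3 (0.96 log units; beyond the scatter), so at this position the number depends on the hydrogen on the aromatic nitrogen of the group, not merely on a ring being present. Nothing at hand explains this difference. Open, as far as these compounds go, is how other groups on this carbon would read, such as an amine, a carboxylic acid or a phenyl ring, and whether any would match compound 1.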